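Cyano on the Acetamide Chain and Kinetic Solubility

The compounds below may be only part of what the source reports. "The series", "measured", "known", "first", "only" and "open" are said of these compounds alone.

The study compares two acetamide cores carrying the same dichlorophenyl group. Compound 1 `CC(=O)Nc1nc(-c2ccc(Cl)c(Cl)c2)cs1` and compound 2 `N#CCC(=O)Nc1nc(-c2ccc(Cl)c(Cl)c2)cs1` share one core, while compound 3 `CC(=O)NC1=NN(c2ccc(Cl)c(Cl)c2)CC1` and compound 4 `N#CCC(=O)NC1=NN(c2ccc(Cl)c(Cl)c2)CC1` share a second; how the two cores differ is not broken down here.

All were, or are to be, tested in a physicochemical assay for solubility, measured as kinetic solubility, with a stated time of 1 h, at pH 7.4; on this read-out lower numbers stand for lower solubility and higher numbers for higher solubility. For compound 1 this assay reports only a limit, < 1000 nM, and not a number. Compound 2 gives 57000 nM in this assay. Compound 3 gives 31000 nM in this assay, a value that sits within the scatter of that of compound 2, so no order between them can be claimed.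

The measured step of an at least 57-fold higher number from compound 1 to compound 2 (1.75 log units; beyond the scatter) follows from the change (cyano in place of hydrogen on a saturated chain carbon bound to a carbonyl carbon). Its size is known only as a lower bound due to the limit of < 1000 nM in this assay, at which 1 of the 3 values shown sits, so the true rise may be larger.

Compound 4 carries the same change on the second core, (cyano in place of hydrogen on a saturated chain carbon bound to a carbonyl carbon), with the entering group at the same place in both pairs. For the measured compounds named here, since the one measured instance of this change raised the number considerably, and compound 3 already starts from 31000 nM, a rise is expected for compound 4 as well. The expected step is a 3.9-fold higher number from compound 3 to compound 4 (0.59 log units; beyond the scatter), resting on the measured step from compound 1 to compound 2. Compound 4 is therefore estimated to give 120000 nM in this assay, within a range from 40000 nM to 400000 nM.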

Compound 4, solubility: 202000 nM
Beside the measured number, compound 4's estimate is 1.7-fold (0.23 log units) below it; low and high end bracket the measured number.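

In this assay, cyano in place of hydrogen on a saturated chain carbon bound to a carbonyl carbon gives a 6.5-fold higher number from compound 3 to compound 4 (0.81 log units; beyond the scatter), so the rise seen on the core of compound 1 recurs on the core of compound 3, in the same direction and beyond the scatter. On the first core the change gives an at least 57-fold higher number from compound 1 to compound 2 (1.75 log units; beyond the scatter), but compound 1 is reported only as a limit, so the two steps cannot be ranked by size, because the first is known only as a lower bound: the limit of < 1000 nM in this assay, at which 1 of the 4 values shown sits. The two pairs therefore show that the direction of this change carried over between these two cores, but they do not show that its size carried over, that it would hold on any further core, or why the number rises.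

The compounds shown leave open whether an amine or a carboxylic acid on the same saturated chain carbon bound to a carbonyl carbon would move the number as cyano does. They also leave open what a longer chain ending in a nitrile would do on either core.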